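A few compounds are considered here, and "the series" means these few. Any claim that something is new, unique, unknown or untested is made for them only; others in the source may bear on it.

In a functional assay on MGC-803 cells (Homo sapiens) for inhibition, read by MTT assay, with a stated time of 48 h (on this read-out lower numbers stand for stronger inhibition and higher numbers for weaker inhibition), compound 1 `C/C=C/C=C/C(=O)N(Cc1ccc(OC)c(O)c1)c1cc(OC)c(OC)c(OC)c1` gives 140 nM, the lowest of the two numbers seen so far. Compound 2 `C/C=C/C(=O)N(Cc1ccc(OC)c(F)c1)c1cc(OC)c(OC)c(OC)c1` gives 1650 nM, a gap well beyond the usual scatter, though the two structures differ in more than one place, so no single change can be tied to that gap. Compound 3 `COc1ccc(CN(C(=O)CBr)c2cc(OC)c(OC)c(OC)c2)cc1O` has not yet been measured and differs from compound 1 in one place only: bromomethyl in place of penta-1,3-dien-1-yl on a carbonyl carbon. Within the data shown here, no pair of measured compounds separated by a single change is available, so there is no measured step of this kind to lean on. The expected step, a 2.1-fold higher number from compound 1 to compound 3 (0.33 log units; beyond the scatter), is a modest move toward a higher number, one that could as well fall within the scatter. The estimated value for compound 3 in this assay is 300 nM, with a range from 60 nM to 1500 nM.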

Compound 3, half-maximal inhibitory concentration: 140 nM
The estimate for compound 3 lay 2.1-fold (0.33 log units) above the measured number; measured number inside the range.
By their numbers in this assay, from the lowest: compounds 1 and 3 (each within the scatter of the next); then compound 2.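

Among these compounds, putting bromomethyl in place of penta-1,3-dien-1-yl on a carbonyl carbon gives the first single-change step in this assay and reads as no change at the digits printed from compound 1 to compound 3 (within the scatter). For this pair, the longer chain with its 2 double bonds is therefore not needed to keep the number where it stands, and a much smaller group with a bromine atom serves equally well on this read-out. No measured evidence is available to explain why these two different groups give matching numbers.

On these data alone, whether this match extends to other groups on the same carbonyl carbon remains open, for example a plain methyl, a chloromethyl or an aminomethyl group. It is also unknown whether bromomethyl would give the same result with other changes elsewhere on the shared core.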